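The source may hold more compounds than are shown below. What is called first, only, known or untested is meant among the compounds shown, and "the series" means these compounds.

Measured so far:
- compound 1, `Oc1cccc(-c2cc(-c3ccc(Cl)cc3)nc(-c3ccco3)c2)c1`: 8190 nM
- compound 2, `Oc1cccc(-c2cc(-c3ccco3)nc(-c3ccccc3Cl)c2)c1`: 1860 nM
- compound 3, `Oc1cccc(-c2cc(-c3cccc(Cl)c3)nc(-c3ccccn3)c2)c1`: "not determined" (no result reported)

In an ADME assay on HEK293 cells (Homo sapiens) for cytotoxicity, read by CCK-8 assay and cell counting, with a stated time of 2 days (a higher number here means a weaker inhibitor, a lower number a stronger inhibitor), compound 1 gives 8190 nM, while compound 2 gives 1860 nM. Compound 3 was included in the study, but no number for it was reported. Among the two numbers available, compound 2 stands lowest; the only step shown is a 4.4-fold lower number from compound 1 to compound 2 (0.64 log units; beyond the scatter).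

The compound to be measured next is compound 4, `Oc1cccc(-c2cc(-c3ccsc3)nc(-c3ccccc3Cl)c2)c1`. It differs from compound 2 in one place: thiophen-3-yl in place of furan-2-yl on an aromatic carbon.

Going by the values given here, the one measured step concerns a different change, the position of chlorine on the chlorophenyl group, and so says nothing direct about swapping one five-membered ring for another. Among the compounds with values here, no measured pair tells how this assay responds to such a swap. With no bearing evidence, the plain expectation is a step of no more than the usual scatter. Compound 4 is therefore estimated to land near 1900 nM, with a likely range from 800 nM to 4500 nM, which corresponds to an expected step of a 1.0-fold higher number from compound 2 to compound 4 (0.01 log units; within the scatter).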

Compound 4, half-maximal inhibitory concentration: 2720 nM
For compound 4 the middle estimate is 1.4-fold (0.16 log units) below the measured one, and the stated range covers the measured number.
By their numbers in this assay, from the lowest: compounds 2 and 4 (each within the scatter of the next); then compound 1.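

Going by these compounds alone, the swap of furan-2-yl for thiophen-3-yl gives the first reading for this position in this assay: a 1.5-fold higher number from compound 2 to compound 4 (0.17 log units; within the scatter). On this carbon next to the ring nitrogen, a five-membered aromatic ring with oxygen and one with sulfur therefore give numbers that cannot be told apart, although the hetero atom and the point of attachment change together, so neither can be judged alone. Nothing available explains why the two rings give such similar numbers.

Going by these compounds, what remains open is how this carbon responds to a group of another kind, such as an amine, a carboxylic acid or a longer chain. Also open, on these data alone, is whether the same ring swap would give a similar result with the 4-chlorophenyl group of compound 1 in place of 2-chlorophenyl.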